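A few compounds are considered here, and "the series" means these few. Any claim that something is new, unique, unknown or untested is made for them only; others in the source may bear on it.

Measured so far in a functional assay on HL-60 cells (Homo sapiens) for cytotoxicity, read by MTT assay, with a stated time of 48 h; a lower number here means a stronger inhibitor, a higher number a weaker inhibitor:
- compound 1 `Fc1cccc(-c2nc(Nc3ccccc3F)c3cc(F)ccc3n2)c1`: only a limit, > 50000 nM
- compound 2 `Fc1cccc(-c2nc(Nc3cccc(Br)c3)c3cc(F)ccc3n2)c1`: only a limit, > 50000 nM

Compound 2 stands at a limit of this assay, with no number below it. Going by the values given here, the one measured step, a step that the two limits leave unreadable from compound 1 to compound 2, runs between two limits and cannot be read; both values sit at the limit of > 50000 nM in this assay, at which 2 of the 2 values shown sit, so nothing here tells how strongly either compound inhibits.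

Compound 3 `Oc1cccc(Nc2nc(-c3cccc(F)c3)nc3ccc(F)cc23)c1` carries the change (hydroxy in place of bromo on an aromatic carbon). Among the compounds with values here, no measured step bears on this replacement: the step from compound 1 to compound 2 is unreadable, and no other pair is at hand. With both neighbours at the limit, the expected size of an at least 1.6-fold lower number from compound 2 to compound 3 (0.22 log units; that floor lies within the scatter) for compound 3 cannot be anchored, and the estimate rests only on the limit at which compound 2 sits. Compound 3 is therefore expected at about 30000 nM, with a wide range from 5000 nM to 100000 nM.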

Compound 3, half-maximal inhibitory concentration: > 50000 nM
Compound 3 was reported as a limit (the forecaster's own chance of this, stated with the estimate: 60%); middle value at least 1.6-fold (0.22 log units) from the limit.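

Going by these compounds alone, compound 3 also gives only a limit in this assay, so no step among compound 1, compound 2 and compound 3 can be read: the limit of > 50000 nM in this assay, at which 3 of the 3 values shown sit. The compounds shown leave open how strongly any of them inhibits, and whether any group on the nitrogen would give a measurable value.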